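A few compounds are considered here, and "the series" means these few. Any claim that something is new, unique, unknown or untested is made for them only; others in the source may bear on it.

Measured in a functional assay on HL-60 cells (Homo sapiens) for antiproliferative activity, read by MTT assay, with a stated time of 48 h; on this read-out lower numbers stand for stronger inhibition and higher numbers for weaker inhibition:
- compound 1 `CCN(CC)CCn1c(N)c(-c2nc3ccccc3[nH]2)c2nc(C#N)c(C#N)nc21`: 1880 nM
- compound 2 `CCN(CC)CCn1c(N)c(-c2nc3ccccc3n2C)c2nc(C#N)c(C#N)nc21`: 8800 nM
- compound 3 `CN(C)CCn1c(N)c(-c2nc3cc(Cl)ccc3[nH]2)c2nc(C#N)c(C#N)nc21`: > 50000 nM (a limit, not a number)

Compound 3 has no exact number, only (the limit of > 50000 nM in this assay, at which 1 of the 3 values shown sits). Compound 4 `CCN(CC)CCn1c(N)c(-c2nc3cc(Cl)ccc3[nH]2)c2nc(C#N)c(C#N)nc21` differs from it in one place: diethylamino in place of dimethylamino on a saturated chain carbon, two bonds along the chain from an aromatic nitrogen. This puts diethylamino in place of dimethylamino on a saturated chain carbon, two bonds along the chain from an aromatic nitrogen.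

Among the measured compounds shown here, no measured step makes this exact change. For the measured compounds named here, the one measured step, a 4.7-fold higher number from compound 1 to compound 2 (0.67 log units; beyond the scatter), is a different change, methyl in place of hydrogen on an aromatic nitrogen, so it shows only that one small edit can move a value beyond the scatter. The closest guide is a neighbouring compound. Compound 4 carries a chlorine that compound 1 lacks, but both share the diethylamino group, and compound 1 gives 1880 nM. A move towards a lower number in this assay is therefore expected, though its size is uncertain. The expected change is an at least 5.5-fold lower number from compound 3 to compound 4 (0.74 log units; beyond the scatter). For compound 4 the estimated value is 9000 nM, with an expected range of 2000 nM to 40000 nM.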

Compound 4, half-maximal inhibitory concentration: > 50000 nM
Compound 4 was reported as a limit (the forecaster's own chance of this, stated with the estimate: 20%); middle value at least 5.5-fold (0.74 log units) from the limit.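

In this assay, compound 4 is reported only as a limit, not a number, and compound 3 stands at the same limit: the limit of > 50000 nM in this assay, at which 2 of the 4 values shown sit.

The step from dimethylamino to diethylamino therefore cannot be read, but it shows that diethylamino does not bring a chlorine-bearing compound back within the measurable range. The readable steps both involve the chlorine: chloro in place of hydrogen on an aromatic carbon gives an at least 26-fold higher number from compound 1 to compound 4 (1.42 log units; beyond the scatter), while 5-chloro-1H-benzimidazol-2-yl in place of 1-methyl-1H-benzimidazol-2-yl gives an at least 5.6-fold higher number from compound 2 to compound 4 (0.75 log units; beyond the scatter).

The compounds shown leave open how dimethylamino compares with diethylamino when the chlorine is absent. They also leave open whether fluoro or methoxy in the place of chloro, or a morpholine in the place of diethylamino, would give a measurable value.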